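This account rests on a few compounds, and the source may have more. Where it says the series, first, only, none or still open, it means among the compounds named here.

In an ADME assay on Caco-2 cells (Homo sapiens) for inhibition, read by MTT assay, with a stated time of 72 h (on this read-out lower numbers stand for stronger inhibition and higher numbers for weaker inhibition), compound 1 (`COc1cc(/C=C/C(=O)/C=C(/C=C/c2ccc(OC(C)=O)c(OC)c2)NC2CCCCC2)ccc1OC(C)=O`) gives > 25000 nM as its read-out, which is a limit and not a number. Compound 2 (`CCCNC(=C\C(=O)/C=C/c1ccc(O)c(OC)c1)/C=C/c1ccc(O)c(OC)c1`) likewise shows only the limit > 25000 nM and no exact number. Compound 3 (`CC(=O)Oc1ccc(/C=C/C(=O)/C=C(/C=C/c2ccc(OC(C)=O)cc2)NCC(C)C)cc1`) reads > 25000 nM here, again a limit. The whole picture so far is the limit of > 25000 nM in this assay, at which 3 of the 3 values shown sit, and so compound 2 cannot be ranked against the other two.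

Compound 4 (`COc1cc(/C=C/C(=O)/C=C(/C=C/c2ccc(O)c(OC)c2)NCC(C)C)ccc1O`) differs from compound 2 by one small change (methyl in place of hydrogen on a saturated chain carbon bound to two saturated chain carbons): methyl in place of hydrogen on a saturated chain carbon bound to two saturated chain carbons, which turns propylamino to isobutylamino. Within the data shown here, no measured pair shows a change of this kind, so the expectation in this assay is no step beyond the usual scatter, in neither direction. The estimated move is a step that the limit leaves unreadable from compound 2 to compound 4 and is expected to stay small. The expected value for compound 4 is 30000 nM within an estimated range from 12000 nM to 60000 nM and the assay may well report only a limit again.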

Compound 4, half-maximal inhibitory concentration: > 25000 nM
Compound 4: only a limit was reported (the forecaster's own chance of this, stated with the estimate: 80%); the middle value does not contradict the limit.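

No step can be read from compound 2 to compound 4, because each gives only a limit and not a number in this assay: the limit of > 25000 nM in this assay, at which 4 of the 4 values shown sit.

The compounds shown leave open how strongly any of them inhibits, and whether going from propylamino to isobutylamino changes the read-out at all.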